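Carbonyl substituent exchange on the shared core of compound 1

The source may hold more compounds than are shown below. What is called first, only, known or untested is meant among the compounds shown, and "the series" means these compounds.

Compound 1 `CC(C)(Oc1ccc(Cl)cc1)C(=O)N1CCN(c2nc(N)nc3sc(-c4ccc(F)cc4)nc23)CC1` sits at a limit in a functional assay on cells (Lymphocyte, Homo sapiens); on this read-out higher numbers stand for weaker inhibition and lower numbers for stronger inhibition: in this assay compound 1 gives > 10000 nM, which is a limit of the assay and not a number. Compound 2 `Cc1cccc(NC(=O)N2CCN(c3nc(N)nc4sc(-c5ccc(F)cc5)nc34)CC2)c1` gives 300 nM in this assay. Compound 3 `Nc1nc(N2CCN(S(=O)(=O)c3ccccc3)CC2)c2nc(-c3ccc(F)cc3)sc2n1` also sits at a limit; in this assay compound 3 gives > 10000 nM, a limit and not a number. Two of the three values shown thus sit at the limit of > 10000 nM in this assay, at which 2 of the 3 values shown sit.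

Compound 4 `Nc1nc(N2CCN(C(=O)COc3ccc(F)cc3)CC2)c2nc(-c3ccc(F)cc3)sc2n1` is to be measured in this assay. Against compound 1 the change is a group of 9 heavy atoms (7 carbon, 1 oxygen, 1 fluorine; one six-membered aromatic ring of carbon only) in place of a group of 11 heavy atoms (9 carbon, 1 oxygen, 1 chlorine; one six-membered aromatic ring of carbon only), on a carbonyl carbon. Both measured steps pass through compound 2: an at least 33-fold lower number from compound 1 to compound 2 (1.52 log units; beyond the scatter) and an at least 33-fold higher number from compound 2 to compound 3 (1.52 log units; beyond the scatter). Neither tests the (4-fluorophenoxy)methyl group itself; the step from compound 1 to compound 2 only shows that exchanging the group on the carbonyl carbon can move the value far from the limit. Compound 4 is therefore expected to improve somewhat on compound 1 yet remain weak, with an estimated at least 2.0-fold lower number from compound 1 to compound 4 (0.30 log units; that floor lies within the scatter). The estimate for compound 4 in this assay is 5000 nM, with a range of 1000 nM to 20000 nM.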

Compound 4, half-maximal inhibitory concentration: 70 nM
Estimate against measurement, compound 4: 71-fold (1.85 log units) above; measured number outside the range, below it.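

In this assay, a phenoxy-type group on this carbonyl carbon does not by itself hold the value at the limit, as the exchange gives an at least 140-fold lower number from compound 1 to compound 4 (2.15 log units; beyond the scatter). Within the data shown here, the (3-methylphenyl)amino group is also not the only group here that gives a value clear of the limit, and the (4-fluorophenoxy)methyl group goes further, with a 4.3-fold lower number from compound 2 to compound 4 (0.63 log units; beyond the scatter). On the amine nitrogen in the ring, the ((4-fluorophenoxy)methyl)carbonyl group also separates sharply from phenylsulfonyl, with an at least 140-fold lower number from compound 3 to compound 4 (2.15 log units; beyond the scatter).

Going by these compounds, the true sizes of the two largest steps stay unknown, since compound 1 and compound 3 stand at a limit of the assay and not at a number: the limit of > 10000 nM in this assay, at which 2 of the 4 values shown sit. Also open are how the change divides between the halogen exchange and the carbons lost, and how a longer chain or an amine in this group would read.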